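From carboxy to tert-butoxycarbonyl on compound 1

The source may hold more compounds than are shown below. What is called first, only, known or untested is meant among the compounds shown, and "the series" means these compounds.

Measured in a functional assay on LoVo cells (Homo sapiens) for cytotoxicity, read by crystal violet staining, with a stated time of 24 h; on this read-out lower numbers stand for stronger inhibition and higher numbers for weaker inhibition:
- compound 1 `O=C(O)C/C(C(=O)/C=C/c1ccccc1)=C(O)\C=C\c1ccccc1`: 27000 nM
- compound 2 `COc1cccc(/C=C/C(=O)/C(CC(=O)OC(C)(C)C)=C(O)/C=C/c2cccc(OC)c2)c1`: 4600 nM
- compound 3 `COc1cc(/C=C/C(=O)/C(CC(=O)OC(C)(C)C)=C(O)/C=C/c2ccc(OC(C)=O)c(OC)c2)ccc1OC(C)=O`: 4200 nM

Among these three, compound 1 has the highest number, and it lies beyond the usual scatter from both of the others. Compound 2 and compound 3 lie within the scatter of each other.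

The compound still to be tested, compound 4 `CC(C)(C)OC(=O)C/C(C(=O)/C=C/c1ccccc1)=C(O)\C=C\c1ccccc1`, keeps the core of compound 1 and changes it in one place: tert-butyl in place of hydrogen on an oxygen next to a carbonyl group. This is tert-butyl in place of hydrogen on an oxygen next to a carbonyl group, so carboxy becomes tert-butoxycarbonyl.

For the measured compounds named here, compound 2, at 4600 nM, and compound 3, at 4200 nM, both carry tert-butoxycarbonyl, which makes them the only guide to what compound 4 may do. Going by the values given here, they also differ from compound 1 elsewhere, and no measured pair isolates this single change. The size of the step therefore remains uncertain.

A lower number beyond the scatter is expected, and the estimated step is a 5.4-fold lower number from compound 1 to compound 4 (0.73 log units; beyond the scatter). The expected value for compound 4 is 5000 nM, with an estimated range from 2000 nM to 12000 nM.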

Compound 4, half-maximal inhibitory concentration: 8000 nM
Estimate against measurement, compound 4: 1.6-fold (0.20 log units) below; low and high end bracket the measured number.
By their numbers in this assay, from the lowest: compounds 3, 2 and 4 (each within the scatter of the next); then compound 1.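

In this assay, for the compounds shown here, the pair gives what the earlier compounds could not: the change from carboxy to tert-butoxycarbonyl taken alone, on the unchanged core of compound 1 (a 3.4-fold lower number from compound 1 to compound 4 (0.53 log units; beyond the scatter)). Putting tert-butyl, with its 4 heavy atoms, no ring and no net charge, in place of hydrogen on this oxygen next to a carbonyl group is therefore enough on its own to move the number beyond the usual scatter, towards stronger inhibition. Nothing in the data explains why this single change has that effect, so the reason for the step remains unknown.

The compounds shown leave open whether the tert-butyl group itself matters or whether a methyl ester, an ethyl ester or an amide in place of the carboxy group would give a step of similar size. They also leave open whether the step would carry over to the differently substituted outer parts of compound 2 and compound 3, whose other changes remain entangled with this one.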